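The source may hold more compounds than are shown below. What is called first, only, known or untested is meant among the compounds shown, and "the series" means these compounds.

Three measured compounds share one core. Compound 1 `COc1cc(/C=C/c2ccc(NC(=O)/C=C/c3ccc(OC)c(OC)c3)cc2)cc(OC)c1` gives 7740 nM in a functional assay on MDA-MB-231 cells (Homo sapiens) for inhibition, read by MTT assay, with a stated time of 48 h; on this read-out higher numbers stand for weaker inhibition and lower numbers for stronger inhibition. Compound 2 `COc1cc(/C=C/c2ccc(NC(=O)/C=C/c3cc(OC)c(O)c(OC)c3)cc2)cc(OC)c1` gives 7130 nM in this assay, and compound 3 `COc1cc(/C=C/c2ccc(NC(=O)/C=C/c3ccc([N+](=O)[O-])cc3)cc2)cc(OC)c1` gives 11700 nM in this assay. Compound 3 thus carries the highest of the three numbers, yet the steps of a 1.5-fold higher number from compound 1 to compound 3 (0.18 log units; within the scatter) and a 1.6-fold higher number from compound 2 to compound 3 (0.22 log units; within the scatter) both fall within the scatter, so no order among the three can be claimed.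

Compound 4 `COc1cc(/C=C/c2ccc(NC(=O)/C=C/c3ccccc3F)cc2)cc(OC)c1` has not been measured. It differs from compound 3 by 2-fluorophenyl in place of 4-nitrophenyl on a double-bonded chain carbon bound to a double-bonded chain carbon. The measured steps that bear on this change are the two in which the group on that chain carbon was exchanged: they are small, and a 1.1-fold lower number from compound 1 to compound 2 (0.04 log units; within the scatter) is small as well. Every exchange of this group so far has stayed within the scatter. On that footing the step expected in this assay is a 1.3-fold lower number from compound 3 to compound 4 (0.11 log units; within the scatter), nothing beyond the scatter in either direction. Compound 4 is therefore estimated at 9000 nM in this assay, within a range from 4000 nM to 20000 nM.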

Compound 4, half-maximal inhibitory concentration: 2380 nM
Estimate against measurement, compound 4: 3.8-fold (0.58 log units) above; the whole stated range lies above it.
By their numbers in this assay, from the lowest: compound 4; then compounds 2, 1 and 3 (each within the scatter of the next).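

In this assay the group on a double-bonded chain carbon bound to a double-bonded chain carbon proves able to move the number: 2-fluorophenyl in place of 4-nitrophenyl gives a 4.9-fold lower number from compound 3 to compound 4 (0.69 log units; beyond the scatter) and the same group entering elsewhere gives a 3.0-fold lower number from compound 2 to compound 4 (0.48 log units; beyond the scatter) and a 3.3-fold lower number from compound 1 to compound 4 (0.51 log units; beyond the scatter). All three steps lie beyond the scatter, so compound 4 stands apart from compound 1, compound 2 and compound 3, whose exchanges of this group had all stayed within the scatter. Nothing shown here explains this difference.

Among the compounds shown here, with 2-fluorophenyl the only fluorine-bearing group at this place, it remains open whether the lower number depends on the fluorine at all. From the compounds shown here alone, an unsubstituted phenyl or a chlorophenyl at the same place would test this, and whether either would match compound 4 is unknown.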